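Swapping Nitro for Hydroxy on the Aryl Tail

This account rests on a few compounds, and the source may have more. Where it says the series, first, only, none or still open, it means among the compounds named here.

Compound 1, `COc1ccc(S(=O)(=O)N2CCc3cccc(-c4ccc([N+](=O)[O-])cc4)c32)cc1`: 51.3 nM
Compound 2, `COc1ccc(S(=O)(=O)n2ccc3cccc(-c4ccc(C#N)cc4)c32)cc1`: 146 nM
Compound 3, `COc1ccc(S(=O)(=O)N2CCc3cccc(-c4c(F)c(F)c(F)c(F)c4F)c32)cc1`: 4630 nM

Of the compounds shown here, three built on a shared core have been tested in a functional assay on KB-VIN10 cells (Homo sapiens) for inhibition, with a stated time of 72 h; a higher number here means a weaker inhibitor, a lower number a stronger inhibitor. Compound 1 gives the lowest number of the three; compound 2 stands higher by a margin beyond the usual scatter, and compound 3 stands far higher still. Compound 4, `COc1ccc(S(=O)(=O)N2CCc3cccc(-c4ccc(O)cc4)c32)cc1`, differs from compound 1 by hydroxy in place of nitro on an aromatic carbon. Within the data shown here, no measured pair shows this change, so its size is uncertain. Compound 1 is the reference for the expected step of a 3.9-fold higher number from compound 1 to compound 4 (0.59 log units; beyond the scatter), which is expected to weaken inhibition modestly. Compound 4 is therefore estimated at 200 nM in this assay, with a likely range from 50 nM to 800 nM.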

Compound 4, half-maximal inhibitory concentration: 123 nM
Compound 4: middle estimate off by 1.6-fold (0.21 log units), on the high side; the range from low to high includes it.
By their numbers in this assay, from the lowest: compound 1; then compounds 4 and 2 (each within the scatter of the next); then compound 3.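

Putting hydroxy in place of nitro on this aromatic carbon gives, in this assay, a 2.4-fold higher number from compound 1 to compound 4 (0.38 log units; beyond the scatter) as the first direct measure of a change at this position. The step is modest, so nitro is not needed here for inhibition in the nanomolar range, and a group with a hydrogen-bond donor is tolerated in its place. Nothing measured here explains the size of this step. Going by these compounds, whether an amine or a carboxylic acid at the same position would keep inhibition remains open, as does whether this step would repeat on another core.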